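This account rests on a few compounds, and the source may have more. Where it says the series, first, only, none or still open, it means among the compounds named here.

Measured so far in a functional assay on MDA-MB-468 cells (Homo sapiens) for antiproliferative activity, read by MTT assay; a lower number here means a stronger inhibitor, a higher number a weaker inhibitor:
- compound 1, `Cc1cc(Nc2ccc(F)cc2)nc(Nc2ccc(NS(=O)(=O)c3ccc(C(F)(F)F)cc3)cc2)n1`, gives 32300 nM.
- compound 2, `COc1ccc(Nc2cc(C)nc(Nc3ccc(NS(=O)(=O)c4ccccc4Cl)cc3)n2)cc1`, gives a limit, > 50000 nM.
- compound 3, `COc1ccc(Nc2cc(C)nc(Nc3ccc(NS(=O)(=O)c4c(Cl)cc(C)cc4OC)cc3)n2)cc1`, gives a limit, > 50000 nM.

Compound 2 therefore stands not at a number but at a limit of this assay, (the limit of > 50000 nM in this assay, at which 2 of the 3 values shown sit). Compound 3 sits at that same limit, so the step that the two limits leave unreadable from compound 2 to compound 3 cannot be read in size or direction. Compound 4, `COc1ccc(Nc2ccc(Nc3nc(C)cc(Nc4ccc(OC)cc4)n3)cc2)cc1`, differs from compound 2 in one place: 4-methoxyphenyl in place of (2-chlorophenyl)sulfonyl on a nitrogen on an aromatic ring. For the measured compounds named here, no measured step bears on this change. Going by the values given here, the only step in hand, from compound 2 to compound 3, is unreadable, and compound 1 carries a different group on the sulfonyl sulfur and gives a weak number of its own. Nothing in these three values argues for a shift beyond the scatter, so the expectation for compound 4 rests on compound 2 alone. Compound 4 is estimated at 50000 nM, with a range of 20000 nM to 150000 nM, and most likely reported as a limit again. The step this estimate implies is a number no higher from compound 2 to compound 4 (the limit leaves the size open).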

Compound 4, half-maximal inhibitory concentration: > 50000 nM
Compound 4 gave a limit, no number; the forecaster's own chance of this, stated with the estimate: 60%; the middle value sits exactly at the limit.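

In this assay compound 4 gives > 50000 nM, which is a limit and not a number. Compound 2 stands at the same limit, so no step from compound 2 to compound 4 can be read: the limit of > 50000 nM in this assay, at which 3 of the 4 values shown sit.

As far as these compounds go, whether 4-methoxyphenyl in place of (2-chlorophenyl)sulfonyl changes the activity at all, and in which direction, stays open.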